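Ethoxyphenyl Analogue of a Spiro Oxindole Quinoxaline Series

A few compounds are considered here, and "the series" means these few. Any claim that something is new, unique, unknown or untested is made for them only; others in the source may bear on it.

Among the measured compounds shown here, compound 1 `N#CC1=C(N)Oc2c(c3nc4ccccc4nc3c3ccccc23)C12C(=O)N(Cc1cnnn1-c1cccc(Cl)c1)c1ccccc12` is the only member of this small set with a definite number in an ADME assay on L02 cells (Homo sapiens) for antiproliferative activity, read by MTT assay, with a stated time of 48 h; a lower number here means a stronger inhibitor, a higher number a weaker inhibitor: compound 1 gives 35200 nM. Compound 2 `N#CC1=C(N)Oc2c(c3nc4ccccc4nc3c3ccccc23)C12C(=O)N(Cc1cnnn1-c1ccccc1Br)c1ccccc12` reaches only a limit of this assay, as compound 2 gives > 50000 nM. Compound 3 `COc1ccc(-n2nncc2CN2C(=O)C3(C(C#N)=C(N)Oc4c3c3nc5ccccc5nc3c3ccccc43)c3ccccc32)cc1` likewise stops at a limit, as compound 3 gives > 50000 nM. The two limits stand out as the limit of > 50000 nM in this assay, at which 2 of the 3 values shown sit. The steps of an at least 1.4-fold higher number from compound 1 to compound 2 (0.15 log units; that floor lies within the scatter) and an at least 1.4-fold higher number from compound 1 to compound 3 (0.15 log units; that floor lies within the scatter) both run the same way, while the step that the two limits leave unreadable from compound 2 to compound 3 cannot be read.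

Compound 4 `CCOc1ccc(-n2nncc2CN2C(=O)C3(C(C#N)=C(N)Oc4c3c3nc5ccccc5nc3c3ccccc43)c3ccccc32)cc1` has not been measured. Compared with compound 1, it carries 4-ethoxyphenyl in place of 3-chlorophenyl on an aromatic nitrogen. The nearest measured step is that from compound 1 to compound 3, where a 4-methoxyphenyl on the same aromatic nitrogen gave a number at the limit; the 4-ethoxyphenyl of compound 4 is a close relative of that group. On this basis compound 4 is expected to give a weaker result, probably at or near the limit, with the estimated step of a 1.6-fold higher number from compound 1 to compound 4 (0.19 log units; within the scatter). For compound 4 the estimate is 55000 nM, with a range from 25000 nM to 120000 nM.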

Compound 4, half-maximal inhibitory concentration: > 50000 nM
Compound 4: only a limit was reported; the forecaster's own chance of this, stated with the estimate: 65%; the middle value does not contradict the limit.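

The result adds a third group on this aromatic nitrogen, the 4-ethoxyphenyl, that leaves the reading at a limit of this assay, so that the 3-chlorophenyl of compound 1 alone gives a definite number: the limit of > 50000 nM in this assay, at which 3 of the 4 values shown sit.
The change itself gives an at least 1.4-fold higher number from compound 1 to compound 4 (0.15 log units; that floor lies within the scatter), which is only a floor. The steps to compound 4 from compound 2 and from compound 3 cannot be read, since both ends of each are limits, so the methyl that separates compound 3 from compound 4 has no readable size here.

On these data alone, how far the true values of compound 2, compound 3 and compound 4 lie beyond the limit stays open. So does whether a phenyl ring carrying an amine or a carboxylic acid on this nitrogen would give a definite number in this assay.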